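Swapping an aromatic ring for a pentyl chain

The source may hold more compounds than are shown below. What is called first, only, known or untested is meant among the compounds shown, and "the series" means these compounds.

Measured compounds:
compound 1 `O=C1c2ccccc2C(=O)N1C/C=C/Cn1cc(C#CCCc2ccccc2)c(=O)[nH]c1=O` 29000 nM
compound 2 `CCCCCc1ccc(C#Cc2cn(C/C=C/CN3C(=O)c4ccccc4C3=O)c(=O)[nH]c2=O)cc1` 27000 nM

Both compounds were tested in a functional assay on HeLa cells (Homo sapiens) for antiproliferative activity, read by MTT assay, with a stated time of 3 days; a higher number here means a weaker inhibitor, a lower number a stronger inhibitor. Compound 2 has the lower of the two numbers, but the step of a 1.1-fold lower number from compound 1 to compound 2 (0.03 log units; within the scatter) lies within the scatter, so the two compounds cannot be told apart on these data.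

Compound 3 `CCCCCC#Cc1cn(C/C=C/CN2C(=O)c3ccccc3C2=O)c(=O)[nH]c1=O` is the next compound, and its change from compound 2 is pentyl in place of 4-pentylphenyl on a triple-bonded carbon. Within the data shown here, the only measured step that touches this position is a 1.1-fold lower number from compound 1 to compound 2 (0.03 log units; within the scatter), in which one group on the same triple-bonded carbon was exchanged for another with no shift beyond the scatter. Among the measured compounds shown here, no measured step shows a ring being replaced by an open chain, so the expectation for compound 3 rests on that one step alone. A step of about a 1.1-fold higher number from compound 2 to compound 3 (0.05 log units; within the scatter) is expected, that is, nothing beyond the scatter. Compound 3 is therefore estimated at 30000 nM, within a range from 12000 nM to 80000 nM.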

Compound 3, half-maximal inhibitory concentration: 91000 nM
The estimate for compound 3 lay 3.0-fold (0.48 log units) below the measured number, and the stated range ends below it.
By their numbers in this assay, from the lowest: compounds 2 and 1 (each within the scatter of the next); then compound 3.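

The triple-bonded carbon does not accept every group equally: compound 1 and compound 2 could not be told apart, but replacing 4-pentylphenyl with pentyl gives a 3.4-fold higher number from compound 2 to compound 3 (0.53 log units; beyond the scatter). The other step to the same compound, propyl in place of phenyl on a saturated chain carbon, two bonds along the chain from a triple-bonded carbon, gives a 3.1-fold higher number from compound 1 to compound 3 (0.50 log units; beyond the scatter), so among these three compounds, both steps that remove the aromatic ring raise the number. Nothing measured here speaks to the reason for this shift.

As far as these compounds go, it remains open whether the loss of the ring or the smaller group matters more, as pentyl has fewer heavy atoms than 4-pentylphenyl. The compounds shown also do not tell how a longer chain such as decyl, or a chain ending in an amine, would behave here.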